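A few compounds are considered here, and "the series" means these few. Any claim that something is new, unique, unknown or untested is made for them only; others in the source may bear on it.

In a functional assay on K562 cells (Homo sapiens) for cytotoxicity, read by MTT assay, with a stated time of 72 h (on this read-out higher numbers stand for weaker inhibition and lower numbers for stronger inhibition), compound 1 `C=C1C(=O)[C@@]23C(=O)OC[C@]4(C(=O)CCC(C)(C)[C@H]4C=O)[C@@H]2CC[C@@H]1[C@H]3O` reads 2180 nM while compound 2 `C=C1C(=O)[C@@]23C(=O)OC[C@]4(C(=O)CCC(C)(C)[C@H]4C=O)[C@@H]2CC[C@@H]1[C@H]3OC(=O)c1ccc(OC)cc1` reads 1650 nM and compound 3 `C=C1C(=O)[C@@]23C(=O)OC[C@]4(C(=O)CCC(C)(C)[C@H]4C=O)[C@@H]2CC[C@@H]1[C@H]3OC(=O)c1ccc(F)cc1` reads 2700 nM on the same scale. Compound 3 cannot be separated from the other two: a 1.2-fold higher number from compound 1 to compound 3 (0.09 log units; within the scatter) and a 1.6-fold higher number from compound 2 to compound 3 (0.21 log units; within the scatter) are the steps that place it. For the measured compounds named here, the change to compound 4 `C=C1C(=O)[C@@]23C(=O)OC[C@]4(C(=O)CCC(C)(C)[C@H]4C=O)[C@@H]2CC[C@@H]1[C@H]3OC(=O)c1ccccc1F` is 2-fluorophenyl in place of 4-fluorophenyl on a carbonyl carbon and no measured step covers it directly. The nearest evidence is a 1.6-fold higher number from compound 2 to compound 3 (0.21 log units; within the scatter) for a swap on the same aromatic ring, along with a 1.3-fold lower number from compound 1 to compound 2 (0.12 log units; within the scatter) and a 1.2-fold higher number from compound 1 to compound 3 (0.09 log units; within the scatter) for adding the whole aromatic carbonyl group. No step beyond the scatter is therefore expected in this assay for this change. The step expected is a 1.2-fold lower number from compound 3 to compound 4 (0.07 log units; within the scatter) with no direction to be relied on. Compound 4 is estimated at 2300 nM within an expected range from 1200 nM to 4500 nM on this read-out.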

Compound 4, half-maximal inhibitory concentration: 2860 nM
Compound 4: middle estimate off by 1.2-fold (0.09 log units), on the low side, within the range that was stated.
By their numbers in this assay, from the lowest: compounds 2, 1, 3 and 4 (each within the scatter of the next).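

In this assay the place of the fluoro on the ring now has a direct reading: 2-fluorophenyl in place of 4-fluorophenyl gives a 1.1-fold higher number from compound 3 to compound 4 (0.03 log units; within the scatter) and does not separate the pair. The other two steps, a 1.7-fold higher number from compound 2 to compound 4 (0.24 log units; within the scatter) and a 1.3-fold higher number from compound 1 to compound 4 (0.12 log units; within the scatter) show that this isomer also stays within the scatter of the 4-methoxyphenyl compound and the free hydroxyl compound. Nothing at hand accounts for this flat picture. Open, from the compounds shown here alone, is whether any group on this oxygen can move the number beyond the scatter. An aminomethyl or carboxylic acid on the ring, or a longer alkyl chain on the carbonyl, would test that.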